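This account rests on a few compounds, and the source may have more. Where it says the series, first, only, none or still open, it means among the compounds named here.

Compound 1 `Nc1cc(N)c2nc(-c3ccccc3)c(Oc3ccc(Cl)c(Cl)c3)nc2c1` in a functional assay on SF-295 cells (Homo sapiens) for inhibition, read by sulforhodamine B assay, with a stated time of 48 h (on this read-out lower numbers stand for higher toxicity in this test and higher numbers for lower toxicity in this test), gives 69200 nM. Among the compounds with values here, that is the only plain number; the other two values are limits of the assay. Compound 2 `CCOC(=O)[C@H](CCC(=O)O)NC(=O)c1ccc(Sc2nc3cc(N)cc(N)c3nc2-c2ccccc2)cc1` stops at a limit in this assay, < 100000 nM. Compound 3 `CCOC(=O)[C@H](CCC(=O)O)NC(=O)c1ccc(Oc2nc3cc(N)cc(N)c3nc2-c2ccccc2)cc1` likewise stops at a limit in this assay, < 100000 nM. Within the data shown here, two of the three values thus share the same limit (the limit of < 100000 nM in this assay, at which 2 of the 3 values shown sit), leaving compound 1 as the one compound with a measured number, and no step between measured compounds can be drawn from these three.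

Compound 4 `Nc1cc(N)c2nc(-c3ccccc3)c(NCc3ccc(F)cc3)nc2c1` has not yet been measured. It differs from compound 1 in one place: (4-fluorobenzyl)amino in place of 3,4-dichlorophenoxy on an aromatic carbon of the shared core, next to the ring nitrogen and ortho to a phenyl group. Among the measured compounds shown here, no measured pair in the set carries this change, so nothing here tells the size of its effect. The expectation for compound 4 in this assay is a step of a 1.4-fold lower number from compound 1 to compound 4 (0.14 log units; within the scatter) that does not go beyond the usual scatter of repeated measurements. Compound 4 is therefore estimated at 50000 nM, with a range from 12000 nM to 100000 nM.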

Compound 4, concentration lethal to 50% of the cells: 64600 nM
Beside the measured number, compound 4's estimate is 1.3-fold (0.11 log units) below it; low and high end bracket the measured number.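

Within the data shown here, the step from 3,4-dichlorophenoxy to (4-fluorobenzyl)amino on this aromatic carbon of the shared core gives the first reading for this position in this assay: a 1.1-fold lower number from compound 1 to compound 4 (0.03 log units; within the scatter). The two groups differ in their link to the core and in their halogens, and the entering group brings a hydrogen-bond donor that the leaving group lacks, yet the read-out does not separate compound 1 from compound 4. In this one pair, then, neither the aryl ether link nor the two chlorine atoms is needed for a number of this size in this assay, although a single pair cannot show how far that holds for other groups at this position.

Still open, going by these compounds, is whether a much smaller group here, such as an unsubstituted amine, or a carboxylic acid or a longer chain in place of the (4-fluorobenzyl)amino group, would move the number beyond the scatter. Compounds 2 and 3 each stand at a limit and not at a number, so they add no comparison with this pair: the limit of < 100000 nM in this assay, at which 2 of the 4 values shown sit.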